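Working notes: tolerated concentration in the shared core series

The source may hold more compounds than are shown below. What is called first, only, known or untested is meant among the compounds shown, and "the series" means these compounds.

compound 1 `Nc1nc(NC2CC2)c2ncn(/C=C3/CC3(CO)CO)c2n1`: in an ADME assay on HFF cells (Homo sapiens) for cytotoxicity, with a stated time of 8 days (a lower number here means that less compound is tolerated, a higher number that more compound is tolerated), compound 1 gives > 300000 nM, a limit of the assay.
compound 2 `Nc1nc(NCc2ccccc2)c2ncn(/C=C3/CC3(CO)CO)c2n1`: in this assay compound 2 gives > 300000 nM, a limit of the assay.
compound 3 `Nc1nc(NC2CCCC2)c2ncn(/C=C3/CC3(CO)CO)c2n1`: in this assay compound 3 gives > 300000 nM, a limit of the assay.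

All three values sit at the limit of > 300000 nM in this assay, at which 3 of the 3 values shown sit, so the steps a step that the two limits leave unreadable from compound 1 to compound 2, a step that the two limits leave unreadable from compound 1 to compound 3 and a step that the two limits leave unreadable from compound 2 to compound 3 cannot be sized. Compound 3 therefore stands only at the limit, with no number of its own.

Compound 4 `COCCOc1nc(N)nc2c1ncn2/C=C1/CC1(CO)CO` differs from compound 3 by 2-methoxyethoxy in place of cyclopentylamino on an aromatic carbon. Among the measured compounds shown here, no measured step in this assay bears on this change; the measured steps are all unreadable. Compound 4 is expected to remain at the limit, with the step of a number no higher from compound 3 to compound 4 (the limit leaves the size open) estimated as no step beyond the scatter. The estimate for compound 4 is 300000 nM, with a range from 100000 nM to 1000000 nM.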

Compound 4, half-maximal cytotoxic concentration: > 300000 nM
Compound 4 gave a limit, no number; the forecaster's own chance of this, stated with the estimate: 80%; the middle value lies on the limit itself.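

No new step can be read between compound 4 and compound 1, compound 2 or compound 3, because all four compounds stand at the same limit: the limit of > 300000 nM in this assay, at which 4 of the 4 values shown sit.

The compounds shown leave open whether cyclopropylamino, benzylamino, cyclopentylamino and 2-methoxyethoxy differ at all in this assay.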